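The compounds below may be only part of what the source reports. "The series", "measured", "known", "first", "only" and "open" are said of these compounds alone.

Compound 1 `C=CCO/N=C(\C#N)C(=O)NCC1=NOC(C(C)(C)C)C1`: > 100 ug/mL
Compound 2 `C=CCO/N=C(\C)C(=O)NCC1=NOC(C(C)(C)C)C1`: > 100 ug/mL

Both entries are limits of the assay, not numbers. From the compounds shown here alone, in a functional assay on MDBK cells (Bos taurus) for cytotoxicity (a higher number here means that more compound is tolerated, a lower number that less compound is tolerated), compound 2 gives > 100 ug/mL, which is a limit, so its exact position is unknown. Compound 1 gives > 100 ug/mL, also a limit. The evidence so far is the limit of > 100 ug/mL in this assay, at which 2 of the 2 values shown sit.

Compound 3 `C=CCO/N=C(\CC)C(=O)NCC1=NOC(C(C)(C)C)C1` differs from compound 2 by a small change: methyl in place of hydrogen on a saturated chain carbon bound to a carbon with a double bond to nitrogen. This places methyl in place of hydrogen on a saturated chain carbon bound to a carbon with a double bond to nitrogen, so methyl becomes ethyl.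

For the measured compounds named here, the only measured step that bears on this is a step that the two limits leave unreadable from compound 1 to compound 2, which involves the same carbon with a double bond to nitrogen. It gives no size to carry over. No change beyond the scatter is therefore expected in this assay, and the expected step is a step that the limit leaves unreadable from compound 2 to compound 3. For compound 3 the estimate is 150 ug/mL, with an expected range from 70 ug/mL to 400 ug/mL.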

Compound 3, half-maximal cytotoxic concentration: > 100 ug/mL
Compound 3: a limit, no number; the forecaster's own chance of this, stated with the estimate: 85%; the middle value lies beyond the limit too.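

In this assay compound 3 gives > 100 ug/mL, which is a limit and not a number. Compound 1 and compound 2 also stand at limits, so no step among these three compounds can be read. The compounds shown leave open how much of each compound the cells tolerate, and whether exchanging cyano, methyl and ethyl changes that at all.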